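Ethyl to methyl on the shared core

A few compounds are considered here, and "the series" means these few. Any claim that something is new, unique, unknown or untested is made for them only; others in the source may bear on it.

In an ADME assay on HEL cells (Homo sapiens) for cytotoxicity (a higher number here means that more compound is tolerated, a lower number that less compound is tolerated), compound 1 (`CCCc1nn([C@H]2C[C@H](O)[C@@H](CO)S2)c(=O)[nH]c1=O`) gives > 40000 nM, which is a limit of the assay. Compound 2 (`Cc1nn([C@H]2C[C@H](O)[C@@H](CO)S2)c(=O)nc1N`) gives > 40000 nM, also a limit. Compound 3 (`CCc1nn([C@H]2C[C@H](O)[C@@H](CO)S2)c(=O)nc1O`) has no result reported, so it has no place of its own on the numbers. Compound 4 (`Cc1nn([C@H]2C[C@H](O)[C@@H](CO)S2)c(=O)nc1O`) is still unmeasured. The change leading to it is hydrogen in place of methyl on a saturated chain carbon bound to an aromatic carbon, in words hydrogen in place of methyl on a saturated chain carbon bound to an aromatic carbon, which turns ethyl into methyl. Going by the values given here, no measured step covers this change, and no shift beyond the scatter is expected in this assay. Compound 4 is expected at 40000 nM, with an estimated range of 20000 nM to 60000 nM.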

Compound 4, half-maximal cytotoxic concentration: 166000 nM
Compound 4: the middle estimate sits 4.2-fold (0.62 log units) below what was measured; measured number outside the range, above it.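

No step can be read from compound 2 to compound 4, because compound 2 is only a limit: the limit of > 40000 nM in this assay, at which 2 of the 4 values shown sit. The compounds shown leave open the size of both changes, hydroxy in place of amino and ethyl to methyl.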